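Moving from an aromatic arm to a saturated amine chain

A few compounds are considered here, and "the series" means these few. Any claim that something is new, unique, unknown or untested is made for them only; others in the source may bear on it.

Measured compounds in an assay on HEK293 cells for inhibition of Steryl-sulfatase (Homo sapiens), tested at 1 uM; on this read-out lower numbers stand for a weaker effect and higher numbers for a stronger effect at the one concentration tested:
- compound 1 `CCN(Cc1ccccn1)c1cccc(C(=O)N2CCc3ccc(OS(N)(=O)=O)cc3C2)c1`: 19.9%
- compound 2 `CCN(Cc1ccccc1)c1ccc(C(=O)N2CCc3ccc(OS(N)(=O)=O)cc3C2)cc1`: 83.6%
- compound 3 `NS(=O)(=O)Oc1ccc2c(c1)CN(C(=O)c1ccc(N(Cc3ccccc3)Cc3ccco3)cc1)CC2`: 98.2%

Compound 1 gives the lowest of the three readings in this assay; compound 2 sits well above it and compound 3 higher still, both gaps beyond the scatter. Within the data shown here, the only measured step that changes one place at a time is a number 14.6 percentage points higher from compound 2 to compound 3 (beyond the scatter), and it concerns a change on a saturated chain carbon bound to a nitrogen on an aromatic ring, not the change now in question.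

Compound 4 `CN(CCCN1CCCCC1)c1cccc(C(=O)N2CCc3ccc(OS(N)(=O)=O)cc3C2)c1` differs from compound 1 in a single place: methyl(3-(piperidin-1-yl)propyl)amino in place of ethyl((pyridin-2-yl)methyl)amino on an aromatic carbon. The group enters on an aromatic carbon of a six-membered aromatic ring of carbon only, meta to a large group. Among the measured compounds shown here, no measured step speaks to swapping an aromatic arm for a saturated chain carrying a non-aromatic ring, so the direction is open. Compound 1 being weak at 19.9% leaves room upward, but nothing shown demands it.

Compound 4 is expected to show a step of a number 10.1 percentage points higher from compound 1 to compound 4 (beyond the scatter) in this assay. The estimate for compound 4 is 30%, between 5% and 65%.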

Compound 4, a percentage reported as inhibition, at one concentration (the size of the read-out at that concentration, not a potency): 30.6%
The estimate for compound 4 lay 0.6 percentage points below the measured number, within the range that was stated.
By their numbers in this assay, from the lowest: compound 1; then compound 4; then compound 2; then compound 3.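

In this assay, putting methyl(3-(piperidin-1-yl)propyl)amino in place of ethyl((pyridin-2-yl)methyl)amino on an aromatic carbon, meta to a large group, gives a number 10.7 percentage points higher from compound 1 to compound 4 (beyond the scatter) and so moves the reading up rather than down. At this place, then, the six-membered aromatic ring with 1 hetero atom in the arm can give way to a six-membered non-aromatic ring with 1 hetero atom at the end of a saturated chain without any loss, though the gain is modest. No measurement here explains the rise.

Because the change swaps the whole arm at once, these compounds leave open whether the ring, the chain or the methyl on the nitrogen accounts for the step. As far as these compounds go, it also remains open how a morpholine ring in place of the piperidine, or a shorter two-carbon chain, would read at this place.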